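A few compounds are considered here, and "the series" means these few. Any claim that something is new, unique, unknown or untested is made for them only; others in the source may bear on it.

Compound 1 `CCN(CC)c1ccc2cc(C(=O)c3ccc(N4CCN(C(=O)CN5CCNCC5)CC4)cc3)oc2c1` was tested in an ADME assay on L02 cells (Homo sapiens) for cytotoxicity, read by MTT assay, with a stated time of 48 h; on this read-out lower numbers stand for stronger inhibition and higher numbers for weaker inhibition. In this assay compound 1 gives only a limit, > 100000 nM. Compound 2 `CCN(CC)c1ccc2cc(C(=O)c3ccc(N4CCN(C(=O)CN5CCN(S(=O)(=O)C6CC6)CC5)CC4)cc3)oc2c1` likewise gives only a limit, > 100000 nM. Compound 3 `CCN(CC)c1ccc2cc(C(=O)c3ccc(N4CCN(C(=O)CN5CCN(Cc6ccc(C#N)cc6)CC5)CC4)cc3)oc2c1` gives a readable number, 29600 nM. The scale of the whole set is fixed by the limit of > 100000 nM in this assay, at which 2 of the 3 values shown sit. Compound 4 `CCN(CC)c1ccc2cc(C(=O)c3ccc(N4CCN(C(=O)CN5CCN(CC(C)=O)CC5)CC4)cc3)oc2c1` is compound 1 with one change: 2-oxopropyl in place of hydrogen on an amine nitrogen in a ring. The measured steps that bear on this are a step that the two limits leave unreadable from compound 1 to compound 2 and an at least 3.3-fold lower number from compound 1 to compound 3 (0.52 log units; beyond the scatter). Only the 4-cyanobenzyl group produced a readable drop, and the entering 2-oxopropyl group has no ring. Compound 4 is therefore expected to stay near the limit, at 100000 nM within 40000 nM to 300000 nM, which means a number no higher from compound 1 to compound 4 (the limit leaves the size open).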

Compound 4, half-maximal inhibitory concentration: > 100000 nM
Compound 4: a limit, no number; the forecaster's own chance of this, stated with the estimate: 65%; the middle value lies on the limit itself.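

In this assay, compound 4 gives only a limit, so its steps to compound 1 and compound 2 cannot be read. Going by these compounds alone, the one readable step is an at least 3.3-fold higher number from compound 3 to compound 4 (0.52 log units; beyond the scatter): with the chain carbon on the ring nitrogen kept, acetyl in place of 4-cyanophenyl loses the drop seen with compound 3. Most of the set now sits at a single ceiling: the limit of > 100000 nM in this assay, at which 3 of the 4 values shown sit.

On these data alone, compound 3 alone gives a readable number, so it stays open whether that drop depends on the ring or on the nitrile of 4-cyanobenzyl. A plain benzyl group on the same nitrogen would separate the two.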